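Phosphate-bearing amide in place of a carboxylic acid

This account rests on a few compounds, and the source may have more. Where it says the series, first, only, none or still open, it means among the compounds named here.

Compounds measured so far:
compound 1, `CC(C)c1onc(-c2c(Cl)cccc2Cl)c1COc1ccc(N(C)Cc2ccc(CCC(=O)O)cc2)c(C(F)(F)F)n1`, 55%
compound 2, `CC(C)c1onc(-c2c(Cl)cccc2Cl)c1COc1ccc(N(C)Cc2cccc(C(=O)O)c2)c(C(F)(F)F)n1`, 89%
compound 3, `CN(Cc1cccc(C(=O)O)c1)c1ccc(OCc2c(-c3c(Cl)cccc3Cl)noc2C2CC2)nc1C(F)(F)F`, 79%

In a functional assay on HEK293 cells for agonist activity at Bile acid receptor (Homo sapiens) (a lower number here means a smaller maximal response, a higher number a larger maximal response), compound 2 stands highest of the three numbers. Compound 3 lies nearest; the step of a number 10 percentage points lower from compound 2 to compound 3 (within the scatter) stays within the scatter, so the two cannot be ordered. Compound 1 lies furthest away, and the step of a number 34 percentage points higher from compound 1 to compound 2 (beyond the scatter) is large and beyond the scatter.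

Compound 4, `CC(C)c1onc(-c2c(Cl)cccc2Cl)c1COc1ccc(N(C)Cc2cccc(C(=O)NCCOP(=O)(O)O)c2)c(C(F)(F)F)n1`, has not yet been measured. It differs from compound 2 in one place: a group of 8 heavy atoms (2 carbon, 1 nitrogen, 4 oxygen, 1 phosphorus; no ring) in place of one oxygen atom, on a carbonyl carbon.

Going by the values given here, no measured step bears directly on this change, since the carboxylic acid is present in all three measured compounds. The step from compound 1 to compound 2 shows only that where the acid sits on its phenyl ring matters strongly, while the step from compound 2 to compound 3 concerns a different part of the molecule. Because compound 2 gives 89% with the acid at the place of change and that acid is here replaced by a different group, a lower number in this assay is expected for compound 4 than for compound 2, as a number 24 percentage points lower from compound 2 to compound 4 (beyond the scatter), with wide uncertainty. Compound 4 is estimated at 65%, between 30% and 95%.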

Compound 4, largest response reached (reported as efficacy), in percent of the reference or control that the assay uses: 48%
Compound 4: the middle estimate sits 17 percentage points above what was measured; the measured number falls inside the stated range.
By their numbers in this assay, from the lowest: compounds 4 and 1 (each within the scatter of the next); then compounds 3 and 2 (each within the scatter of the next).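

In this assay, the change at the carbonyl carbon gives a number well down on the parent acid: the phosphate-bearing amide group of 8 heavy atoms in place of the hydroxy gives a number 41 percentage points lower from compound 2 to compound 4 (beyond the scatter). Going by these compounds alone, the earlier steps moved the acid on its phenyl ring or changed the group on another aromatic carbon, and every one of those compounds kept the carboxylic acid, so this is the first sign that the response is sensitive to what stands on the carbonyl carbon itself. The free carboxylic acid is still not strictly required for a response, as compound 4 reaches 48% without it. Nothing available here accounts for the drop.

The compounds shown leave open which part of the new group carries the loss: the amide link, the two-carbon chain or the terminal phosphate. Going by these compounds, a plain primary amide, a 2-hydroxyethyl amide lacking the phosphate, or an amide ending in a carboxylic acid or sulfonic acid would separate these parts, and it also remains open whether the same exchange behaves alike with the cyclopropyl group of compound 3.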